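The source may hold more compounds than are shown below. What is called first, only, known or untested is meant among the compounds shown, and "the series" means these compounds.

Compound 1 `COc1ccc(-c2nc3ccccn3c2C(=O)/C=C\Nc2cnc3ccccc3c2)cc1` and compound 2 `O=C(/C=C\Nc1cnc2ccccc2c1)c1c(-c2ccccc2)nc2ccccn12` share a core and differ in one place. In a functional assay on DU-145 cells (Homo sapiens) for cytotoxicity, read by MTT assay, with a stated time of 48 h (a higher number here means a weaker inhibitor, a lower number a stronger inhibitor), compound 1 gives 5280 nM, and compound 2 gives 2440 nM. The change between them is hydrogen in place of methoxy on an aromatic carbon, and it produced a 2.2-fold lower number from compound 1 to compound 2 (0.34 log units; beyond the scatter).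

Compound 3 `COc1cc(N/C=C\C(=O)c2c(-c3ccc(Cl)cc3)nc3ccccn23)cc(OC)c1OC` gives 3250 nM in this assay. The difference between the cores of compound 1 and compound 3 is not broken down here; compound 3 stands within the scatter of compound 2 and of compound 1.

Compound 4 `COc1cc(N/C=C\C(=O)c2c(-c3ccc(Cl)cc3)nc3ccccn23)cc(OC)c1` has not yet been measured. It differs from compound 3 by hydrogen in place of methoxy on an aromatic carbon. This is the same kind of change as that from compound 1 to compound 2, but the surroundings of the place are not identical: in compound 3 the carbon that loses its methoxy is ortho to two methoxy groups, whereas in compound 1 it is not. On the evidence of compound 1 and compound 2, where the step was a 2.2-fold lower number from compound 1 to compound 2 (0.34 log units; beyond the scatter), a modest lowering of the number is expected, estimated as a 1.6-fold lower number from compound 3 to compound 4 (0.21 log units; within the scatter). Compound 4 is therefore expected to give 2000 nM in this assay, with an expected range from 900 nM to 4500 nM.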

Compound 4, half-maximal inhibitory concentration: 12000 nM
Compound 4: the middle estimate sits 6.0-fold (0.78 log units) below what was measured; the whole stated range lies below it.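

In this assay, hydrogen in place of methoxy on an aromatic carbon gave a 3.7-fold higher number from compound 3 to compound 4 (0.57 log units; beyond the scatter), so the direction of the change seen with compound 1 and compound 2 did not carry over to this pair. Set side by side, the two steps run in opposite directions and do not agree: the same change on two cores in this assay, a 2.2-fold lower number (0.34 log units; beyond the scatter) from compound 1 to compound 2 and a 3.7-fold higher number (0.57 log units; beyond the scatter) from compound 3 to compound 4, 8.0-fold (0.90 log units) apart, beyond the scatter of two such steps This shows that, in this series, the step measured on one core is no reliable guide to the same change on another, but it does not show what separates the two results, and two pairs cannot tell whether the surroundings of the methoxy group or some other difference between the cores matters.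

The compounds shown leave open how the same change behaves on further cores in this series. They also leave open whether an amine, a hydroxy group or a fluorine atom at the place of the methoxy group lost from compound 3 would follow hydrogen or methoxy.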